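The compounds below may be only part of what the source reports. "The series", "measured", "known", "first", "only" and "open" are said of these compounds alone.

In a functional assay on L1210 cells (Mus musculus) for antiproliferative activity, with a stated time of 48 h (on this read-out lower numbers stand for stronger inhibition and higher numbers for weaker inhibition), compound 1 `C=C(Br)C(=O)Nc1ccc(/C=C/C(=O)c2ccc(Cl)cc2)cc1` gives 1100 nM, compound 2 `C=C(Br)C(=O)Nc1ccc(C(=O)/C=C/c2ccc(OC)cc2)cc1` gives 900 nM and compound 3 `C=C(Br)C(=O)Nc1ccc(C(=O)/C=C/c2cccc(OC)c2)cc1` gives 1100 nM. Compound 3 is thus level with compound 1 and within the scatter of compound 2. Compound 4 `C=C(Br)C(=O)Nc1ccc(C(=O)/C=C/c2cccc(OC)c2OC)cc1` differs from compound 3 by one change: methoxy in place of hydrogen on an aromatic carbon, a methoxy in place of hydrogen on an aromatic carbon, ortho to a large group and ortho to a methoxy group. Among the compounds with values here, the one measured step that bears on it swaps 4-methoxyphenyl for 3-methoxyphenyl, a 1.2-fold higher number from compound 2 to compound 3 (0.09 log units; within the scatter). That step relocates a methoxy rather than adding one, so it guides only loosely. No change beyond the scatter is therefore expected in this assay, and the expected step is a 1.1-fold lower number from compound 3 to compound 4 (0.04 log units; within the scatter). Compound 4 is expected at 1000 nM, with an estimated range of 450 nM to 2200 nM.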

Compound 4, half-maximal inhibitory concentration: 1100 nM
Compound 4: middle estimate off by 1.1-fold (0.04 log units), on the low side; the measured number falls inside the stated range.
By their numbers in this assay, from the lowest: compounds 2, 1, 3 and 4 (each within the scatter of the next).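

In this assay, adding a methoxy in place of hydrogen on an aromatic carbon, ortho to a large group and ortho to a methoxy group, gives no change at the digits printed from compound 3 to compound 4 (within the scatter). Within the data shown here, the earlier step only relocated a methoxy, so this is the first read on adding one to the ring, and at this position the addition leaves the number unmoved. No supporting data bear on this result.

Still open, going by these compounds, is whether an amine, a hydroxy group or a longer alkoxy chain here would behave alike. Also open, on these data alone, is whether this methoxy gives the same number without the methoxy group already present.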